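Cyclopropylmethyl in place of fluorobenzyl on the shared core

The compounds below may be only part of what the source reports. "The series", "measured", "known", "first", "only" and "open" are said of these compounds alone.

Measured compounds:
compound 1 `O=C(CCCCCn1cc(Nc2ncc3ccn(Cc4ccccc4F)c3n2)cn1)NO`, 15.3 nM
compound 2 `O=C(CCCCCCn1cc(Nc2ncc3ccn(Cc4ccccc4F)c3n2)cn1)NO`, 8.4 nM
compound 3 `O=C(CCCCCn1cc(Nc2ncc3ccn(Cc4cccc(Cl)c4)c3n2)cn1)NO`, 34.4 nM

In an assay on isolated protein for inhibition of protein deacetylase HDAC6 (Homo sapiens), with a stated time of 60 min (on this read-out lower numbers stand for stronger inhibition and higher numbers for weaker inhibition), compound 2 gives 8.4 nM, the lowest number of the three; compound 1 lies nearest, a 1.8-fold lower number from compound 1 to compound 2 (0.26 log units; within the scatter), and compound 3 lies furthest, the gap beyond the scatter. Going by the values given here, the only change at the group on the saturated chain carbon bound to an aromatic nitrogen is the aryl swap in a 2.2-fold higher number from compound 1 to compound 3 (0.35 log units; beyond the scatter).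

Compound 4 `O=C(CCCCCCn1cc(Nc2ncc3ccn(CC4CC4)c3n2)cn1)NO` is unmeasured. It differs from compound 2 by cyclopropyl in place of 2-fluorophenyl on a saturated chain carbon bound to an aromatic nitrogen. Among the compounds with values here, no measured step replaces an aryl group with a small non-aromatic ring here, so the direction rests on the one aryl swap alone, which gave a modest higher number. A step of similar or somewhat larger size toward a higher number is therefore expected, with the estimate for compound 4 kept wide: compound 4 is expected at 22 nM, range 8 nM to 60 nM, meaning an expected 2.6-fold higher number from compound 2 to compound 4 (0.42 log units; beyond the scatter).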

Compound 4, half-maximal inhibitory concentration: 16 nM
Compound 4: the middle estimate sits 1.4-fold (0.14 log units) above what was measured; low and high end bracket the measured number.
By their numbers in this assay, from the lowest: compounds 2, 1 and 4 (each within the scatter of the next); then compound 3.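

In this assay the change from 2-fluorobenzyl to cyclopropylmethyl is a 1.9-fold higher number from compound 2 to compound 4 (0.28 log units; within the scatter) and so stays within the scatter, which shows that the group on the saturated chain carbon bound to an aromatic nitrogen need not be aromatic to keep the number of compound 2. Cyclopropyl has 3 heavy atoms against 7 in 2-fluorophenyl and no fluorine, so neither the six-membered aromatic ring nor the fluorine is required at this place on the chain of compound 2. No measured evidence bears on the origin of this result.

Open, from the compounds shown here alone, is whether cyclopropylmethyl reads the same on the chain of compound 1, where the aryl swap gave a 2.2-fold higher number from compound 1 to compound 3 (0.35 log units; beyond the scatter) as a step beyond the scatter. Also open, going by these compounds, is how an amine, a carboxylic acid or a plain methyl would read at this place.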